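This account rests on a few compounds, and the source may have more. Where it says the series, first, only, none or still open, it means among the compounds named here.

In an ADME assay on HepG2 cells (Homo sapiens) for inhibition, with a stated time of 72 h (on this read-out lower numbers stand for an effect already at smaller amounts and higher numbers for an effect only at larger amounts of compound), compound 1 `O=C(Nc1ccc(Cl)cc1)c1cc([N+](=O)[O-])ccc1Cl` reaches only the assay limit, > 25000 nM. Compound 2 `C=CC(=O)Nc1cccc(-c2nc3ccccc3s2)c1` likewise gives only a limit, > 25000 nM, in this assay. Going by the values given here, both readings sit together at the limit of > 25000 nM in this assay, at which 2 of the 2 values shown sit, so no step between measured compounds can be drawn. Compound 3 `C/C=C/C(=O)Nc1cccc(-c2nc3ccccc3s2)c1` differs from compound 2 by prop-1-en-1-yl in place of vinyl on a carbonyl carbon. Among the compounds with values here, with no measured step in this assay to go on, the expected step that the limit leaves unreadable from compound 2 to compound 3 is none beyond the usual scatter. Compound 3 is therefore estimated at 30000 nM in this assay, within 15000 nM to 80000 nM, and will most likely again be reported only as a limit.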

Compound 3, half-maximal effective concentration: > 25000 nM
Compound 3: a limit, no number; the forecaster's own chance of this, stated with the estimate: 85%; the middle value is on the limit's open side.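

No step can be read between compound 2 and compound 3, since both give only limits in this assay. The compounds shown leave open whether prop-1-en-1-yl in place of vinyl on a carbonyl carbon changes the read-out at all.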